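The compounds below may be only part of what the source reports. "The series", "measured", "known", "first", "only" and "open" are said of these compounds alone.

The series shares one core and varies only the chain on the amine nitrogen. Compound 1 is `CCCCCCCNC[C@@H]1OC[C@H](N)[C@H]1O`; in a functional assay on B16-F10 cells (Mus musculus) for antiproliferative activity, read by MTT assay, with a stated time of 72 h (a higher number here means a weaker inhibitor, a lower number a stronger inhibitor), compound 1 reads only at a limit of the assay, > 128000 nM. Compound 2 is `CCCCCCCCCCCCNC[C@@H]1OC[C@H](N)[C@H]1O`, and in this assay compound 2 gives 58100 nM. Compound 3 is `CCCCCCCCCCNC[C@@H]1OC[C@H](N)[C@H]1O`; in this assay compound 3 likewise reads only at a limit, > 128000 nM. Compound 3 therefore stands at the upper edge of what the assay reports, at the limit of > 128000 nM in this assay, at which 2 of the 3 values shown sit, with no number to anchor it.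

Compound 4 is `CCCCCCCCCNC[C@@H]1OC[C@H](N)[C@H]1O`. It differs from compound 3 as follows: hydrogen in place of methyl on a saturated chain carbon, nine bonds along the chain from an amine nitrogen. The measured steps that bear on this shortening of the chain point one way: an at least 2.2-fold higher number from compound 2 to compound 3 (0.34 log units; beyond the scatter), while a step that the two limits leave unreadable from compound 1 to compound 3, and an at least 2.2-fold lower number from compound 1 to compound 2 (0.34 log units; beyond the scatter) shows that only the longest chain so far gave a number at all. Every shortening of the chain has ended at the limit, so compound 4 is expected to stay there too, the expected step being a step that the limit leaves unreadable from compound 3 to compound 4. The estimate for compound 4 in this assay is 160000 nM, within 100000 nM to 350000 nM, most likely reported only as a limit.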

Compound 4, half-maximal inhibitory concentration: > 128000 nM
Compound 4: a limit, no number (the forecaster's own chance of this, stated with the estimate: 85%); the middle value lies beyond the limit too.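

In this assay compound 4 also reads only at a limit, > 128000 nM. Hydrogen in place of methyl, nine bonds along the chain from the amine nitrogen, thus yields no number, and the only readable step is an at least 2.2-fold higher number from compound 2 to compound 4 (0.34 log units; beyond the scatter), while the steps that join one limit to another cannot be read. Compound 2 remains the only compound here with a number, and the limit now takes in the rest of the series: the limit of > 128000 nM in this assay, at which 3 of the 4 values shown sit.

As far as these compounds go, it remains open whether a chain longer than that of compound 2 would give a lower number, and whether the readable activity begins only at the chain length of compound 2. Also open, from the compounds shown here alone, is how a phenyl or hydroxyl group at the chain end would read, and how far compound 1, compound 3 and compound 4 differ from one another.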